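From 1H-imidazol-2-yl to 1,3-oxazol-2-yl on the shared core

The compounds below may be only part of what the source reports. "The series", "measured", "known", "first", "only" and "open" are said of these compounds alone.

In a physicochemical assay for solubility, in phosphate buffer, with a stated time of 18 h (on this read-out lower numbers stand for lower solubility and higher numbers for higher solubility), compound 3 `CC(C)(C)c1nc(-c2ncc[nH]2)c2c(N)c(C#N)c(N)nc2n1` gives < 1000 nM, which is a limit and not a number. Compound 1 `CC(C)(C)c1nc(-c2nccs2)c2c(N)c(C#N)c(N)nc2n1` gives < 1500 nM, also a limit. Among the compounds with values here, compound 2 `CC(C)(C)c1nc(-c2cccs2)c2c(N)c(C#N)c(N)nc2n1` gives 56000 nM, the only true number among the three.

Compound 4 `CC(C)(C)c1nc(-c2ncco2)c2c(N)c(C#N)c(N)nc2n1` carries 1,3-oxazol-2-yl in place of 1H-imidazol-2-yl on an aromatic carbon, next to the ring nitrogen: 1,3-oxazol-2-yl in place of 1H-imidazol-2-yl on an aromatic carbon.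

Within the data shown here, three measured steps bear on this change. The step of an at least 37-fold higher number from compound 1 to compound 2 (1.57 log units; beyond the scatter) and the step of an at least 56-fold lower number from compound 2 to compound 3 (1.74 log units; beyond the scatter) are both large, and both separate compound 2 from a compound held at a limit. The step that the two limits leave unreadable from compound 1 to compound 3 cannot be read. Thiophen-2-yl in compound 2 is the one group without a ring nitrogen, and it alone gives a number. The entering 1,3-oxazol-2-yl keeps a ring nitrogen, so it resembles 1,3-thiazol-2-yl in compound 1 more than thiophen-2-yl, and a jump on the scale of an at least 37-fold higher number from compound 1 to compound 2 (1.57 log units; beyond the scatter) is not expected. In this assay a modest rise, or no readable change, is therefore expected, and a further limit is quite possible. The estimated step is an at least 2.5-fold higher number from compound 3 to compound 4 (0.39 log units; beyond the scatter). For compound 4 the expected value is 2500 nM, with an estimated range from 500 nM to 15000 nM.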

Compound 4, solubility: 50000 nM
For compound 4 the middle estimate is 20-fold (1.30 log units) below the measured one, and the stated range ends below it.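

In this assay, the steps of an at least 50-fold higher number from compound 3 to compound 4 (1.69 log units; beyond the scatter) and an at least 33-fold higher number from compound 1 to compound 4 (1.52 log units; beyond the scatter) show that a ring nitrogen in the five-membered group at this place does not by itself hold the read-out at a limit, since 1,3-oxazol-2-yl keeps that nitrogen and still gives a true number. Within the data shown here, with a 1.1-fold lower number from compound 2 to compound 4 (0.05 log units; within the scatter), 1,3-oxazol-2-yl and thiophen-2-yl cannot be told apart, so the earlier split between the one group without a ring nitrogen and the rest does not hold, and compound 4 goes against it. The large steps starting from compound 1 give only a minimum size, and compound 1 itself stands at a limit: the limit of < 1500 nM in this assay, at which 1 of the 4 values shown sits.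

Going by these compounds, the step between compound 1 and compound 3 cannot be read, and the true value of compound 3 stays open, as it too stands at a limit: the limit of < 1000 nM in this assay, at which 1 of the 4 values shown sits. Also open is how far this read-out holds up with a six-membered group such as pyridin-2-yl, with 1,3,4-oxadiazol-2-yl, or with an amine or a carboxylic acid at this place on the shared core.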